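The compounds below may be only part of what the source reports. "The series", "measured", "known", "first", "only" and "open" are said of these compounds alone.

Measured compounds:
- compound 1 `N#Cc1cc(-c2nc(C(c3ccc(F)cc3)c3ccc(F)cc3)sc2CC(=O)O)ccc1F`, 80%
- compound 2 `CCC(c1ccccc1)c1nc(-c2ccc(Cl)cc2)c(CC(=O)O)s1`, 50%
- compound 3 `O=C(O)Cc1sc(C(c2ccccc2)c2ccc(F)cc2)nc1-c1ccc(Cl)cc1`, 80%

In an in vitro functional assay on HEK285-7 cells for antagonist activity at prostaglandin D2 receptor 2 (Homo sapiens), read by BRET and beta-arrestin recruitment (a higher number here means a larger maximal response, a lower number a smaller maximal response), compound 1 stands level with compound 3, the two together giving the highest numbers of the three, while compound 2 lies lower by a step beyond the scatter. For the measured compounds named here, the one single-place step measured, a number 30 percentage points higher from compound 2 to compound 3 (beyond the scatter), concerns the saturated chain carbon bound to two aromatic carbons, not the aryl group on the five-membered aromatic ring with 1 nitrogen and 1 sulfur.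

Compound 4 `O=C(O)Cc1sc(C(c2ccc(F)cc2)c2ccc(F)cc2)nc1-c1ccnc(O)c1` differs from compound 1 in that place: 2-hydroxypyridin-4-yl in place of 3-cyano-4-fluorophenyl on an aromatic carbon. Going by the values given here, no measured step touches this aryl group. Compounds 1 and 3 carry different groups there and differ elsewhere too; both give the same number. The change to compound 4 is therefore expected to cost little, with a number 10 percentage points lower from compound 1 to compound 4 (within the scatter) as a small estimated drop. Compound 4 is expected to give 70% in this assay, within 45% to 90%.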

Compound 4, largest response reached (reported as efficacy), in percent of the reference or control that the assay uses: 60%
Estimate against measurement, compound 4: 10 percentage points above; low and high end bracket the measured number.
By their numbers in this assay, from the lowest: compounds 2 and 4 (each within the scatter of the next); then compounds 1 and 3 (each within the scatter of the next).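

In this assay, for the compounds shown here, the step of a number 20 percentage points lower from compound 1 to compound 4 (beyond the scatter) for 2-hydroxypyridin-4-yl in place of 3-cyano-4-fluorophenyl is the first single-place step at this position on the shared core. It shows that the aryl group on this aromatic carbon, next to the ring nitrogen, is not interchangeable for this read-out. Nothing measured here accounts for the change.

The compounds shown leave open whether the hydroxyl or the ring nitrogen of the entering group goes with the lower number. A pyridin-4-yl or 2-methoxypyridin-4-yl group at this position would separate the two.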